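The compounds below may be only part of what the source reports. "The series", "measured", "known", "first", "only" and "open" are said of these compounds alone.

In a physicochemical assay for solubility, read by HPLC, in phosphate buffer, with a stated time of 24 h, at pH 7.4, tested at 100 uM (a higher number here means a more soluble compound, a lower number a less soluble compound), compound 2 (`C[C@@H](Nc1c(NCCCCCC(=O)NO)c(=O)c1=O)c1ccccc1`) gives 80000000 nM and stands level with compound 3 (`Cc1cccc([C@@H](C)Nc2c(NCCCCCC(=O)NO)c(=O)c2=O)c1`) at 89000000 nM in the upper part of the series, while compound 1 (`O=C(CCCCCCNc1c(Nc2ccccc2)c(=O)c1=O)NO`) gives a clearly lower 6000000 nM in this small set. Compound 4 (`Cc1ccc(Nc2c(NCCCCCC(=O)NO)c(=O)c2=O)cc1`) has not yet been measured. The change from compound 2 is 4-methylphenyl in place of 1-phenylethyl on a nitrogen on an aromatic ring and places 4-methylphenyl in place of 1-phenylethyl on a nitrogen on an aromatic ring. Within the data shown here, one measured step bears on part of this change: a 1.1-fold higher number from compound 2 to compound 3 (0.05 log units; within the scatter) shows that a methyl on an aromatic carbon moved the number by no more than the scatter. Among the measured compounds shown here, no measured step covers the loss of 1-phenylethyl itself. The nearest guide is compound 1 at 6000000 nM, which also lacks that group but differs from compound 4 elsewhere, so it points only loosely to a lower number. An expected step of a 6.7-fold lower number from compound 2 to compound 4 (0.82 log units; beyond the scatter) is therefore estimated, downward and beyond the scatter. Compound 4 is estimated at 12000000 nM with an expected range from 4000000 nM to 40000000 nM in this measurement.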

Compound 4, solubility: 8100000 nM
Compound 4: middle estimate off by 1.5-fold (0.17 log units), on the high side, and the stated range covers the measured number.
By their numbers in this assay, from the lowest: compounds 1 and 4 (each within the scatter of the next); then compounds 2 and 3 (each within the scatter of the next).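

In this assay, among these compounds, the change on this nitrogen gives a 9.9-fold lower number from compound 2 to compound 4 (0.99 log units; beyond the scatter), the first step at this position to lie beyond the scatter. Among the compounds shown here, the only earlier step, a 1.1-fold higher number from compound 2 to compound 3 (0.05 log units; within the scatter), stayed within the scatter, so the series now shows that exchanging the whole group on the nitrogen can move the number where adding a methyl on an aromatic carbon of 1-phenylethyl did not. No measurement shown here accounts for the step.

The step combines several differences, since 4-methylphenyl enters with one heavy atom fewer and the defined stereocentre of 1-phenylethyl leaves, and the compounds shown do not separate these. On these data alone, a benzyl group on this nitrogen, or the opposite stereoisomer of 1-phenylethyl, remains open, as does any ring carrying an amine or a carboxylic acid.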